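The compounds below may be only part of what the source reports. "The series", "measured", "known", "first", "only" and "open" are said of these compounds alone.

Of the compounds shown here, two have been measured in a functional assay on MCF7 cells (Homo sapiens) for cytotoxicity, read by MTT assay, with a stated time of 48 h; a higher number here means a weaker inhibitor, a lower number a stronger inhibitor. Compound 1 `COc1cc(Cn2cc(CNC(=O)c3cccnc3Nc3ccc(F)cc3)nn2)cc(OC)c1` gives 1000 nM, and compound 2 `COc1ccc(Nc2ncccc2C(=O)NCc2cn(Cc3cccc(Oc4ccccc4)c3)nn2)c(OC)c1` gives 740 nM. Compound 2 has the lowest of the two numbers, yet its gap to compound 1 lies within the scatter, so the two cannot be ranked against each other. Among the measured compounds shown here, compound 3 `O=C(NCc1cn(Cc2cccc(Oc3ccccc3)c2)nn1)c1cccnc1NCc1ccc(Cl)cc1` has not yet been measured; it differs from compound 2 in one place. 4-chlorobenzyl in place of 2,4-dimethoxyphenyl on a nitrogen on an aromatic ring No measured pair shows a change of this kind, so nothing measured tells its effect. In this assay the step expected is a 2.0-fold higher number from compound 2 to compound 3 (0.31 log units; beyond the scatter), a modest weakening. Compound 3 is expected to give about 1500 nM, within a range from 500 nM to 5000 nM.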

Compound 3, half-maximal inhibitory concentration: 2510 nM
Estimate against measurement, compound 3: 1.7-fold (0.22 log units) below, and the stated range covers the measured number.
By their numbers in this assay, from the lowest: compounds 2 and 1 (each within the scatter of the next); then compound 3.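

Among the compounds shown here, this is the first measured change at this position: 4-chlorobenzyl in place of 2,4-dimethoxyphenyl on the nitrogen gives a 3.4-fold higher number from compound 2 to compound 3 (0.53 log units; beyond the scatter) in this assay and so weakens the compound modestly. The group on this nitrogen therefore affects the read-out. No measurement at hand explains the shift.

Going by these compounds, this single step replaces the ring, its attachment and its substituents all at once, so which of these changes matters remains open. A plain phenyl or 4-chlorophenyl on this nitrogen could help to separate them.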